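A Sulfur-to-Oxygen Ring Swap on Two Sulfonyl Cores

The source may report more compounds than this note shows. Statements on the series, on what has been measured and on what is new or still open speak of the compounds shown alone.

Of the compounds shown here, three have been measured in a functional assay, tested at 100 ug/mL; a higher number here means a stronger effect of the compound at the concentration tested, a lower number a weaker effect. Compound 1, `Cc1ccc(C2CNN=C2S(=O)(=O)CC2=NCCS2)cc1`, gives 45.1% in this assay. Compound 3, `Cc1ccc(C2CNN=C2S(=O)(=O)CC2=NCCO2)cc1`, carries a different five-membered ring on the chain next to the sulfonyl group: a group of 5 heavy atoms (3 carbon, 1 nitrogen, 1 oxygen; one five-membered non-aromatic ring with 2 hetero atoms) in place of a group of 5 heavy atoms (3 carbon, 1 nitrogen, 1 sulfur; one five-membered non-aromatic ring with 2 hetero atoms), on a saturated chain carbon bound to a sulfonyl sulfur. In this assay compound 3 gives 46.8%, and the step of a number 1.7 percentage points higher from compound 1 to compound 3 (within the scatter) lies within the scatter, so the two values cannot be told apart.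

Compound 2, `COc1ccc(-c2noc(-c3ccc(C)cc3)c2S(=O)(=O)CC2=NCCS2)cc1`, rests on a different core; how that core differs from the core of compound 1 is not broken down here. In this assay compound 2 was reported as "not active" (no number reported), and no number was given for it.

Compound 4, `COc1ccc(-c2noc(-c3ccc(C)cc3)c2S(=O)(=O)CC2=NCCO2)cc1`, has not yet been measured. It stands to compound 2 as compound 3 stands to compound 1, the same change at the same place: a group of 5 heavy atoms (3 carbon, 1 nitrogen, 1 oxygen; one five-membered non-aromatic ring with 2 hetero atoms) in place of a group of 5 heavy atoms (3 carbon, 1 nitrogen, 1 sulfur; one five-membered non-aromatic ring with 2 hetero atoms), on a saturated chain carbon bound to a sulfonyl sulfur. Because the step of a number 1.7 percentage points higher from compound 1 to compound 3 (within the scatter) changed nothing beyond the scatter, the same change is expected to leave compound 2 largely where it is. Compound 4 is therefore expected to show only a weak effect in this assay, with a fair chance that it too is reported as not active rather than with a number; its estimated activity is 10%, between 0% and 30%.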

Compound 4, a percentage reported as activity, at one concentration (the size of the read-out at that concentration, not a potency): 77.1%
Estimate against measurement, compound 4: 67.1 percentage points below; measured number above the stated range.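

Among the compounds shown here, compound 2 carries no number in this assay and so no step from compound 2 to compound 4 can be read. The compounds shown leave open whether the same ring change at the same place has a different size on the core of compound 2 than on the core of compound 1. Nothing shown gives a measured reason for the result of compound 4.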